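Replacing the aryl sulfanyl arm of compound 1

A few compounds are considered here, and "the series" means these few. Any claim that something is new, unique, unknown or untested is made for them only; others in the source may bear on it.

Among the measured compounds shown here, compound 1 `CC(C)C[C@H](N)c1cc(C(F)(F)F)ccc1N1CCN(C(=O)CSc2ccc(Cl)cc2Cl)CC1` gives 1500 nM in an assay on HEK293 cells for displacement of a labelled ligand from Melanocortin receptor 4 (Homo sapiens) (on this read-out lower numbers stand for stronger inhibition and higher numbers for weaker inhibition), the second highest of the three numbers measured so far. Compound 2 `CC(C)C[C@H](N)c1cc(C(F)(F)F)ccc1N1CCN(C(=O)COc2cccc3ccccc23)CC1` gives 2600 nM, the step being a 1.7-fold higher number from compound 1 to compound 2 (0.24 log units; within the scatter). Compound 3 `CC(C)C[C@H](N)c1ccccc1N1CCN(C(=O)[C@H](C)Cc2ccc(Cl)cc2F)CC1` differs from compound 1 in several places at once. In this assay compound 3 gives 67 nM. Compound 4 `CC(C)C[C@H](N)c1cc(C(F)(F)F)ccc1N1CCN(C(=O)CCNC2CCCCC2)CC1` carries (cyclohexylamino)methyl in place of (2,4-dichlorophenyl)sulfanyl on a saturated chain carbon bound to a carbonyl carbon. For the measured compounds named here, the only measured step at the same place, from compound 1 to compound 2, exchanged one aromatic group for another and stayed within the scatter; a change to a non-aromatic ring has no measured counterpart here. The number for compound 4 is therefore expected close to that of compound 1, with a wide range, as a 1.3-fold higher number from compound 1 to compound 4 (0.12 log units; within the scatter). Compound 4 is estimated at 2000 nM, between 500 nM and 8000 nM.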

Compound 4, inhibition constant: 4800 nM
Beside the measured number, compound 4's estimate is 2.4-fold (0.38 log units) below it; measured number inside the range.
By their numbers in this assay, from the lowest: compound 3; then compounds 1, 2 and 4 (each within the scatter of the next, the first and the last beyond it).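

Among the compounds shown here, at this saturated chain carbon bound to a carbonyl carbon, (cyclohexylamino)methyl gives a 3.2-fold higher number from compound 1 to compound 4 (0.51 log units; beyond the scatter), the first step here beyond the scatter, so this place does respond modestly to the arm it carries. Measured from the (naphthalen-1-yl)oxy arm, the same group gives a 1.8-fold higher number from compound 2 to compound 4 (0.27 log units; within the scatter), which does not separate those two arms. No available evidence accounts for the shift.

Open, on these data alone, is whether the non-aromatic ring or the amine nitrogen carries the difference; a cyclohexylsulfanyl arm or a (phenylamino)methyl arm would separate the two.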